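Swapping Methyl for Dimethylamino on a Growth Inhibitor

The source may hold more compounds than are shown below. What is called first, only, known or untested is meant among the compounds shown, and "the series" means these compounds.

- Compound 1 `O=c1[nH]c2ccc(-c3csc(-c4ccc(F)c(F)c4)n3)cc2o1`: 290 nM
- Compound 2 `CCc1cc(F)ccc1-c1nc(-c2ccc3[nH]c(=O)oc3c2)cs1`: 13 nM
- Compound 3 `Cc1cc(F)ccc1-c1nc(-c2ccc3[nH]c(=O)n(CCN(C)C)c3c2)cs1`: 3 nM

All three numbers come from a functional assay on SMOV2 cells (Homo sapiens) for antiproliferative activity, read by sulforhodamine B assay, with a stated time of 3 days; on this read-out higher numbers stand for weaker inhibition of growth and lower numbers for stronger inhibition of growth. Compound 2 gives 13 nM and holds the second highest of the three numbers, with compound 3 lower at 3 nM and compound 1 higher at 290 nM on the same scale. Both gaps lie beyond the scatter.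

The next compound, compound 4 `CN(C)Cc1cc(F)ccc1-c1nc(-c2ccc3[nH]c(=O)oc3c2)cs1`, has not been measured yet. Compared with compound 2, it has dimethylamino in place of methyl on a saturated chain carbon bound to an aromatic carbon. For the measured compounds named here, no two measured compounds differ in just one place, so the data offer no direct guide to this change. Compound 3 also carries a dimethylamino group, elsewhere in its structure, and gives 3 nM in this assay, but it differs from compound 2 in more than one way. A modest move towards a higher number, meaning weaker inhibition of growth, is expected, though the uncertainty is wide. The estimated change is a 2.7-fold higher number from compound 2 to compound 4 (0.43 log units; beyond the scatter) on this read-out. For compound 4 the expected value is 35 nM (estimated range 8 nM to 150 nM).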

Compound 4, concentration for 50% growth inhibition: 10 nM
The estimate for compound 4 lay 3.5-fold (0.54 log units) above the measured number; the range from low to high includes it.
By their numbers in this assay, from the lowest: compound 3; then compounds 4 and 2 (each within the scatter of the next); then compound 1.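

Among the compounds shown, compound 2 and compound 4 are the only pair that differ in one place, giving a direct reading of dimethylamino in place of methyl on a saturated chain carbon bound to an aromatic carbon. In this assay, the change is a 1.3-fold lower number from compound 2 to compound 4 (0.11 log units; within the scatter), so ethyl and (dimethylamino)methyl cannot be told apart at this position, even though the new group brings in a nitrogen and a hydrogen-bond acceptor. The data shown offer no independent measurement that could explain this result.

As far as these compounds go, it remains open whether this position would give a similar number with a different amine, such as pyrrolidine or morpholine, with a carboxylic acid, or with a longer chain carrying the dimethylamino group. Compound 3 carries dimethylamino elsewhere but differs from compound 2 in more than one way, so the compounds shown cannot say whether the group has a different effect at that other position.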